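The source may hold more compounds than are shown below. What is called first, only, known or untested is meant among the compounds shown, and "the series" means these compounds.

Compound 1, `Oc1ccc(-c2cc(-c3ccccc3C(F)(F)F)cc(-c3ccccc3O)n2)cc1`, gives 16500 nM in a functional assay on HeLa cells (Homo sapiens) for inhibition; a lower number here means a stronger inhibitor, a higher number a weaker inhibitor. Compound 2, `Oc1ccc(-c2cc(-c3cccc(C(F)(F)F)c3)cc(-c3ccccc3O)n2)cc1`, reaches only > 50000 nM in this assay, a limit rather than a number. Compound 3, `Oc1ccc(-c2cc(-c3ccccc3C(F)(F)F)cc(-c3cccc(O)c3)n2)cc1`, gives 17400 nM in this assay.

Compound 2 arises from compound 1 by 3-(trifluoromethyl)phenyl in place of 2-(trifluoromethyl)phenyl on an aromatic carbon, a step of an at least 3.0-fold higher number from compound 1 to compound 2 (0.48 log units; beyond the scatter); the value of compound 2 is a limit (the limit of > 50000 nM in this assay, at which 1 of the 3 values shown sits). Compound 4, `Oc1ccc(-c2cc(-c3cccc(C(F)(F)F)c3)cc(-c3cccc(O)c3)n2)cc1`, not yet measured, arises from compound 3 by 3-(trifluoromethyl)phenyl in place of 2-(trifluoromethyl)phenyl on an aromatic carbon. The cores of compound 3 and compound 1 differ by 3-hydroxyphenyl in place of 2-hydroxyphenyl on an aromatic carbon, with a step of a 1.1-fold higher number from compound 1 to compound 3 (0.02 log units; within the scatter). Around the place of exchange compound 1 carries a 2-hydroxyphenyl group where compound 3 carries a 3-hydroxyphenyl group, so the change is of the same kind, not the same. Because the step of an at least 3.0-fold higher number from compound 1 to compound 2 (0.48 log units; beyond the scatter) ran to a limit, compound 4 is expected to show a step of a 3.4-fold higher number from compound 3 to compound 4 (0.54 log units; beyond the scatter) in this assay. Compound 4 is estimated at 60000 nM in this assay, between 30000 nM and 150000 nM, quite possibly again only as a limit.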

Compound 4, half-maximal inhibitory concentration: 16200 nM
The estimate for compound 4 lay 3.7-fold (0.57 log units) above the measured number; the measured number lies below the stated range.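

On the core of compound 3, 3-(trifluoromethyl)phenyl in place of 2-(trifluoromethyl)phenyl gives a 1.1-fold lower number from compound 3 to compound 4 (0.03 log units; within the scatter), so in this assay this change did not carry over unaltered from the core of compound 1: the same change on two cores in this assay, an at least 3.0-fold higher number (0.48 log units; beyond the scatter) from compound 1 to compound 2 and a 1.1-fold lower number (0.03 log units; within the scatter) from compound 3 to compound 4, at least 3.2-fold (0.51 log units) apart, beyond the scatter of two such steps

The exchange of 2-hydroxyphenyl for 3-hydroxyphenyl likewise differs between its two cores, with an at least 3.0-fold lower number from compound 2 to compound 4 (0.48 log units; beyond the scatter): the same change on two cores in this assay, a 1.1-fold higher number (0.02 log units; within the scatter) from compound 1 to compound 3 and an at least 3.0-fold lower number (0.48 log units; beyond the scatter) from compound 2 to compound 4, at least 3.2-fold (0.51 log units) apart, beyond the scatter of two such steps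

Compound 2 gives only a limit, > 50000 nM, and the data show neither the full size of these gaps nor their cause.

From the compounds shown here alone, it remains open whether the same dependence on the core would appear on other cores of this series. Also open, going by these compounds, is how an amine or a carboxylic acid in place of the trifluoromethyl group would behave.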